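Carboxyethyl for phenyl on the two-carbon chain of compound 3

The compounds below may be only part of what the source reports. "The series", "measured", "known", "first", "only" and "open" are said of these compounds alone.

Compound 1 `C=CCc1ccc2ccccc2c1O` gives 56 nM in an assay on RBL-1 cells with Polyunsaturated fatty acid 5-lipoxygenase (Rattus norvegicus) as the target; on this read-out lower numbers stand for stronger inhibition and higher numbers for weaker inhibition. Compound 2 `Oc1c(Cc2cccnc2)ccc2ccccc12` gives 230 nM in this assay, and compound 3 `Oc1c(CCc2ccccc2)ccc2ccccc12` gives 140 nM, the second highest of the three numbers, within the scatter of compound 2 and beyond the scatter of compound 1. Going by the values given here, the one step at a single place is a 4.1-fold higher number from compound 1 to compound 2 (0.61 log units; beyond the scatter). Compound 4 `O=C(O)CCCCc1ccc2ccccc2c1O` differs from compound 3 by 2-carboxyethyl in place of phenyl on a saturated chain carbon, two bonds along the chain from an aromatic carbon. Among the compounds with values here, no measured step exchanges a ring for a carboxyethyl chain, so the step from compound 1 to compound 2 bears on it only as a sign that a change at the chain end can move the number by a modest amount. Compound 4 is therefore expected to give 350 nM in this assay, between 90 nM and 1400 nM. The expected step of a 2.5-fold higher number from compound 3 to compound 4 (0.40 log units; beyond the scatter) is a modest rise, with a wide range.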

Compound 4, half-maximal inhibitory concentration: 4200 nM
Compound 4: the middle estimate sits 12-fold (1.08 log units) below what was measured, outside the stated range (above it).
By their numbers in this assay, from the lowest: compound 1; then compounds 3 and 2 (each within the scatter of the next); then compound 4.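

At this chain position, the carboxylic acid end brings the first large loss in this assay (a 30-fold higher number from compound 3 to compound 4 (1.48 log units; beyond the scatter)). The loss is also large against the other two chain ends (an 18-fold higher number from compound 2 to compound 4 (1.26 log units; beyond the scatter)) and (a 75-fold higher number from compound 1 to compound 4 (1.88 log units; beyond the scatter)), leaving compound 4 the weakest of the four. No available evidence accounts for this loss.

On these data alone, whether the acid or the chain length matters more stays open; a methyl ester or a shorter acid chain on the shared core would separate the two. As far as these compounds go, how an amine at the chain end would read also stays open.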